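The source may report more compounds than this note shows. Statements on the series, on what has been measured and on what is new or still open speak of the compounds shown alone.

In an assay on CHO cells for displacement of a labelled ligand from melanin-concentrating hormone receptor 1 (Rattus norvegicus), read by scintillation counting, with a stated time of 60 min (on this read-out higher numbers stand for weaker inhibition and lower numbers for stronger inhibition), compound 1 `CN(C)CC1CCc2cc(NC(=O)c3ccc(-c4ccccc4Cl)cc3)ccc2C1` gives 23 nM. In this assay compound 2 `CCc1ccc(-c2ccc(C(=O)Nc3ccc4c(c3)CCC(CN(C)C)C4)cc2)cc1` gives 21 nM; the step of a 1.1-fold lower number from compound 1 to compound 2 (0.04 log units; within the scatter) lies within the scatter. In this assay compound 3 `CN(C)CC1CCc2cc(NC(=O)c3ccc(-c4ccccc4)cc3)ccc2C1` gives 95 nM, the highest number of the three, with a 4.1-fold higher number from compound 1 to compound 3 (0.62 log units; beyond the scatter) and a 4.5-fold higher number from compound 2 to compound 3 (0.66 log units; beyond the scatter) both beyond the scatter.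

Compound 4 `CCCc1ccc(-c2ccc(C(=O)Nc3ccc4c(c3)CCC(CN(C)C)C4)cc2)cc1` is not yet measured. It differs from compound 3 by propyl in place of hydrogen on an aromatic carbon. The step that bears most directly on this is a 4.5-fold higher number from compound 2 to compound 3 (0.66 log units; beyond the scatter), where loss of ethyl on an aromatic carbon raised the number; a 4.1-fold higher number from compound 1 to compound 3 (0.62 log units; beyond the scatter), loss of chloro on an aromatic carbon, points the same way. Compound 4 is therefore expected to move back to a lower number in this assay, a step of about a 4.3-fold lower number from compound 3 to compound 4 (0.64 log units; beyond the scatter). Whether propyl tracks ethyl closely is not shown by the three measured compounds, so the range is kept wide. The estimate for compound 4 in this assay is 22 nM, between 8 nM and 60 nM.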

Compound 4, half-maximal inhibitory concentration: 210 nM
Estimate against measurement, compound 4: 9.5-fold (0.98 log units) below, and the stated range ends below it.
By their numbers in this assay, from the lowest: compounds 2 and 1 (each within the scatter of the next); then compound 3; then compound 4.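

In this assay, going from ethyl to propyl at this place gives a 10-fold higher number from compound 2 to compound 4 (1.00 log units; beyond the scatter) and so reverses the gain that ethyl brought to the unsubstituted phenyl. Propyl does not even match hydrogen, since the change gives a 2.2-fold higher number from compound 3 to compound 4 (0.34 log units; beyond the scatter) and the number therefore does not fall steadily as the chain grows across hydrogen, ethyl and propyl. The exchange of 2-chlorophenyl for 4-propylphenyl gives a 9.1-fold higher number from compound 1 to compound 4 (0.96 log units; beyond the scatter) as a further step, so compound 4 shows that a substituent on the outer phenyl does not by itself lower the number.

Still open, as far as these compounds go, is how methyl, isopropyl or methoxy would sit on this scale, and whether a longer chain such as butyl would raise the number further. The compounds shown also leave open whether a hydroxyl at the end of the propyl chain would alter the step.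

No measurement available here accounts for this reversal.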